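The compounds below may be only part of what the source reports. "The series", "measured", "known", "first", "only" and "open" are said of these compounds alone.

Two compounds of the series have been run in an assay on COS-7 cells for inhibition of patatin-like phospholipase domain-containing protein 2 (Mus musculus); a higher number here means a weaker inhibitor, a lower number a stronger inhibitor. Compound 1 `CCOC(=O)c1ccc(-c2ccc(OCC)cc2)[nH]1` reaches only a limit there, > 200000 nM. Within the data shown here, compound 2 `CCOC(=O)c1cccc(-c2ccc(O)cc2)c1` gives 100000 nM, the only number among the values shown in this assay. Compound 3 `CCOC(=O)c1cccc(-c2ccc(N(C)C)cc2)c1` follows from compound 2 by one change: dimethylamino in place of hydroxy on an aromatic carbon. Among the measured compounds shown here, no step between measured compounds exists to gauge such a change, so no shift beyond the scatter is expected in this assay, and the estimated step is no change at the digits printed from compound 2 to compound 3 (within the scatter). Compound 3 is therefore expected at 100000 nM, within 30000 nM to 300000 nM.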

Compound 3, half-maximal inhibitory concentration: 40000 nM
Estimate against measurement, compound 3: 2.5-fold (0.40 log units) above; the range from low to high includes it.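

Dimethylamino in place of hydroxy on an aromatic carbon, para to a large group, gives a 2.5-fold lower number from compound 2 to compound 3 (0.40 log units; beyond the scatter) in this assay, the first step in the series that can be read. The position therefore accepts a larger group, and the hydrogen-bond donor of hydroxy is not needed for a measurable value, since dimethylamino carries none. The step remains modest, and the series still lies close to a limit of the assay: the limit of > 200000 nM in this assay, at which 1 of the 3 values shown sits.

On these data alone, whether the lower number follows from the nitrogen or from its two methyl groups stays open; a primary amine or a methoxy group at this position would separate the two. As far as these compounds go, whether dimethylamino acts the same way on the core of compound 1 also stays open.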